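Naphthyl isomer step in an indolyl pyran series

The source may hold more compounds than are shown below. What is called first, only, known or untested is meant among the compounds shown, and "the series" means these compounds.

Measured so far in a functional assay on MCF7 cells (Homo sapiens) for cytotoxicity, read by MTT assay, with a stated time of 24 h; a higher number here means a weaker inhibitor of growth, a lower number a stronger inhibitor of growth:
compound 1 `N#CC1=C(N)OC(c2c[nH]c3ccccc23)=C(C#N)C1c1ccccc1F`, 48200 nM
compound 2 `N#CC1=C(N)OC(c2c[nH]c3ccccc23)=C(C#N)C1c1ccc2ccccc2c1`, 46600 nM

Compound 2 and compound 1 sit within the scatter of each other; the difference is a change of aryl group on the saturated ring carbon, a 1.0-fold lower number from compound 1 to compound 2 (0.01 log units; within the scatter), with no effect beyond the scatter. Compound 3 `N#CC1=C(N)OC(c2c[nH]c3ccccc23)=C(C#N)C1c1cccc2ccccc12` is unmeasured and differs from compound 2 only in naphthalen-1-yl in place of naphthalen-2-yl on a saturated ring carbon. Within the data shown here, the single measured step bearing on this position suggests that swapping the aryl group there leaves this assay unchanged, so no step beyond the scatter is expected, a 1.0-fold higher number from compound 2 to compound 3 (0.00 log units; within the scatter). Compound 3 is therefore estimated at 47000 nM, with a range of 22000 nM to 100000 nM.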

Compound 3, concentration for total growth inhibition: 33900 nM
Beside the measured number, compound 3's estimate is 1.4-fold (0.14 log units) above it; low and high end bracket the measured number.
By their numbers in this assay, from the lowest: compounds 3, 2 and 1 (each within the scatter of the next).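

In this assay, naphthalen-1-yl in place of naphthalen-2-yl on the saturated ring carbon gives a 1.4-fold lower number from compound 2 to compound 3 (0.14 log units; within the scatter), so the attachment point of this aryl group has no effect beyond the scatter. With a 1.4-fold lower number from compound 1 to compound 3 (0.15 log units; within the scatter), the 2-fluorophenyl, naphthalen-2-yl and naphthalen-1-yl compounds cannot be told apart at this position. No available evidence bears on this result.

As far as these compounds go, whether a phenyl group bearing an amine or a carboxylic acid, or a longer alkyl chain, on this carbon would give a step beyond the scatter remains open. From the compounds shown here alone, the effect of replacing the 1H-indol-3-yl group also remains open.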